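Mirror-image pair: compound 3 and compound 4 in solubility

The source may hold more compounds than are shown below. What is called first, only, known or untested is meant among the compounds shown, and "the series" means these compounds.

Of the compounds shown here, three have been measured in a physicochemical assay for solubility, at pH 7.4; a higher number here means a more soluble compound, a lower number a less soluble compound. Compound 1 `CN1CCN(c2cnc(NCc3c(F)ccc4c3CCO4)n3cnnc23)C1=O` gives 641000 nM, compound 2 `O=C1CCCN1c1cnc(NCc2c(F)ccc3c2CCO3)c2cn[nH]c(=O)c12` gives 66000 nM, and compound 3 `O=C([C@H]1C[C@@H]1c1cccc(N2CCCCC2=O)c1)N1CCN(C2CCC2)CC1` gives 2190000 nM, the highest of the three, with compound 1 nearest and compound 2 furthest away. Compound 4 `O=C([C@@H]1C[C@H]1c1cccc(N2CCCCC2=O)c1)N1CCN(C2CCC2)CC1` is the mirror image of compound 3: the two compounds have the same atoms and bonds and differ only in configuration as drawn: 2 of 2 stereo elements differ (all stereocentres are inverted: mirror images); a stereocentre at a saturated ring carbon is drawn S in compound 3 and R in compound 4; a stereocentre at a saturated ring carbon is drawn S in compound 3 and R in compound 4. Within the data shown here, no pair of measured compounds shows such a change, so no measured step guides the expectation. Because compound 3 stands at 2190000 nM, the step from compound 3 to compound 4 in this assay is expected to be no change at the digits printed from compound 3 to compound 4 (within the scatter), which is no change beyond the scatter. Compound 4 is therefore estimated at 2190000 nM, with a range from 1000000 nM to 4500000 nM.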

Compound 4, solubility: > 3000000 nM
Compound 4 was reported as a limit (the forecaster's own chance of this, stated with the estimate: 5%); at least 1.3-fold (0.13 log units) between middle value and limit.
By their numbers in this assay, from the lowest: compound 2; then compound 1; then compound 3. At a limit, above all of these: compound 4.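

Compound 4 gives > 3000000 nM in this assay, and this is a limit, not a number. Read against that limit, the inversion of both stereocentres is an at least 1.3-fold higher number from compound 3 to compound 4 (0.13 log units; that floor lies within the scatter), so this pair shows no step beyond the scatter, though the limit does not fix its true size. This is the first pair here that allows configuration alone to be read: the fact that compounds 3 and 4 differ only in the configuration as drawn

As far as these compounds go, how far compound 3 and compound 4 truly lie apart stays open. Also open, from the compounds shown here alone, is what a carboxylic acid or a longer chain on the core of compound 3 would do in this assay.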